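Alkyne replacement of the fluoropyridinyl alkene in the series

The compounds below may be only part of what the source reports. "The series", "measured", "known", "first", "only" and "open" are said of these compounds alone.

For the measured compounds named here, compound 1 `Cc1ccc(-n2nccn2)c(C(=O)N2C[C@H](/C=C\c3ccc(F)cn3)CC[C@H]2C)c1` is the only member of this set with a numerical result: in a functional assay on isolated protein for antagonist activity at Orexin receptor type 2 (Homo sapiens), read by FLIPR and calcium flux (on this read-out lower numbers stand for stronger inhibition and higher numbers for weaker inhibition), compound 1 gives 417 nM, and it therefore stands alone as the reference point for everything that follows. Going by the values given here, compound 2 `Cc1ccc(-n2nccn2)c(C(=O)N2C[C@H](C#Cc3cc(CO)ccn3)CC[C@H]2C)c1` and compound 3 `Cc1ccc(-n2nccn2)c(C(=O)N2C[C@H](C#Cc3ccc(CO)cn3)CC[C@H]2C)c1` carry the same core with an ethynyl linker to a hydroxymethyl-substituted pyridine, but in this assay compound 2 gives "not determined" (no result reported) and compound 3 gives "not determined" (no result reported), so they offer no anchor for a comparison, and no step between two measured compounds is available anywhere in the set.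

Compound 4 `Cc1ccc(-n2nccn2)c(C(=O)N2C[C@H](C#Cc3cnccc3O)CC[C@H]2C)c1` is the open question. Relative to compound 1 the change is 2-(4-hydroxypyridin-3-yl)ethynyl in place of 2-(5-fluoropyridin-2-yl)ethenyl on a saturated ring carbon. Among the compounds with values here, with no measured step to lean on, the expectation is a modest shift from compound 1 to compound 4 in this assay, most plausibly toward somewhat weaker inhibition, though a result within the usual scatter of compound 1 would not be surprising. The expected step is a 1.6-fold higher number from compound 1 to compound 4 (0.19 log units; within the scatter). On that basis compound 4 is estimated at 650 nM in this assay, with a range from 150 nM to 2800 nM, the width reflecting the absence of any second number in the set.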

Compound 4, half-maximal inhibitory concentration: 52 nM
Compound 4: middle estimate off by 13-fold (1.10 log units), on the high side; the whole stated range lies above it.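

In this assay, for the compounds shown here, the saturated ring carbon carrying this substituent proves sensitive to what is attached there: 2-(4-hydroxypyridin-3-yl)ethynyl in place of 2-(5-fluoropyridin-2-yl)ethenyl gives an 8.0-fold lower number from compound 1 to compound 4 (0.90 log units; beyond the scatter), the first readable step. Both groups count the same number of heavy atoms, so the gain in inhibition does not come with a larger substituent, but the swap alters the linker, the point of attachment on the pyridine and the ring substituent all at once, and the entering group carries a hydrogen-bond donor that the leaving group lacks. Nothing measured here accounts for the size of this step.

From the compounds shown here alone, the steps involving compound 2 and compound 3 cannot be read, so the contributions of the ethynyl linker and the hydroxypyridine to the gain cannot be separated, and the effect of moving a substituent around the pyridine remains unknown. Also open, going by these compounds, is whether the hydroxy group itself matters, a question that a methoxy group, an amine or a carboxylic acid at that ring position would address.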